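Trading a Furan Ring on a Growth Inhibitor

The compounds below may be only part of what the source reports. "The series", "measured", "known", "first", "only" and "open" are said of these compounds alone.

In a functional assay on SK-N-SH cells (Homo sapiens) for inhibition, read by sulforhodamine B assay (on this read-out higher numbers stand for weaker inhibition of growth and lower numbers for stronger inhibition of growth), compound 1 `CC1(C)CCC[C@]2(C)[C@@H](/C=C/C3=CCOC3=O)C(C=O)=CC(=O)[C@@H]12` gives 38700 nM, compound 2 `CC1(C)CCC[C@]2(C)[C@@H](/C=C/C3=CC(=O)OC3)C(CO)=C(O)C(=O)[C@@H]12` gives 12100 nM, and compound 3 `CC1=CC(=O)[C@H]2C(C)(C)CCC[C@]2(C)[C@H]1/C=C/c1ccoc1` gives 11600 nM. Compound 3 therefore stands level with compound 2, within the scatter, and clearly lower than compound 1. Compound 4 `CC1=CC(=O)[C@H]2C(C)(C)CCC[C@]2(C)[C@H]1/C=C/C1=CCOC1=O` keeps the core of compound 3 but replaces its furan-3-yl, on a double-bonded chain carbon bound to a double-bonded chain carbon: a group of 6 heavy atoms (4 carbon, 2 oxygen; one five-membered non-aromatic ring with 1 hetero atom) in place of a group of 5 heavy atoms (4 carbon, 1 oxygen; one five-membered aromatic ring with 1 hetero atom), on a double-bonded chain carbon bound to a double-bonded chain carbon. Within the data shown here, no measured pair isolates this swap. Compound 1 carries the same entering ring on a different core and gives 38700 nM, so a slight lean toward weaker inhibition is expected in this assay. The estimated step of a 1.6-fold higher number from compound 3 to compound 4 (0.19 log units; within the scatter) stays within the scatter. Compound 4 is expected at 18000 nM, with an estimated range of 7000 nM to 45000 nM.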

Compound 4, concentration for 50% growth inhibition: 8200 nM
Compound 4: middle estimate off by 2.2-fold (0.34 log units), on the high side; the range from low to high includes it.
By their numbers in this assay, from the lowest: compounds 4, 3 and 2 (each within the scatter of the next); then compound 1.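

In this assay, the furan-3-yl can be exchanged for the non-aromatic five-membered ring with no change beyond the scatter, a 1.4-fold lower number from compound 3 to compound 4 (0.15 log units; within the scatter). With that ring kept, methyl in place of formyl on a double-bonded ring carbon gives the clearer step, a 4.7-fold lower number from compound 1 to compound 4 (0.67 log units; beyond the scatter), so here the first real difference comes from the core rather than from the ring on the chain. No measurement at hand explains either step. Still open, going by these compounds, is how a phenyl ring or a chain ending in an amine would fare on the double-bonded chain carbon. Also open, on these data alone, is whether an ethyl group on the double-bonded ring carbon would match methyl.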